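A Methyl Group on the Phenoxy Ring of Compound 1

The source may report more compounds than this note shows. Statements on the series, on what has been measured and on what is new or still open speak of the compounds shown alone.

Measured compounds in an assay on isolated protein for inhibition of Dihydrofolate reductase (Homo sapiens), read by spectrophotometry, using NADPH, with stated times of 5 s and 6 min, tested at 5 uM; a higher number here means a stronger effect of the compound at the concentration tested, a lower number a weaker effect:
compound 1, `NC1=NC2(CCOCC2)N(OCCCOc2ccccc2)C(N)=N1`: > 90%
compound 2, `NC1=NC2(CCOCC2)N(OCCCOc2ccc(Cl)cc2)C(N)=N1`: > 90%
compound 3, `NC1=NC2(CCOCC2)N(OCCCOc2ccccc2Br)C(N)=N1`: 83.8%

Compound 1 sits at a limit of this assay, > 90%, so only a floor is known for it. Compound 2 also returns a limit, > 90%, which is the limit of > 90% in this assay, at which 2 of the 3 values shown sit. Compound 3 gives a number, 83.8%.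

The step to compound 4, `Cc1ccc(OCCCON2C(N)=NC(N)=NC23CCOCC3)cc1`, is methyl in place of hydrogen on an aromatic carbon, that is, phenoxy to 4-methylphenoxy. Going by the values given here, no measured step adds a methyl, but two steps change the same ring. The step that the two limits leave unreadable from compound 1 to compound 2 cannot be sized, and the step of a number at least 6.2 percentage points lower from compound 1 to compound 3 (that floor lies within the scatter) has a floor within the scatter. Neither points to a step beyond the scatter, so compound 4 is expected to stay close to compound 1, with an expected step that the limit leaves unreadable from compound 1 to compound 4. Compound 4 is therefore estimated at 91%, in the range 80% to 99%.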

Compound 4, a percentage reported as inhibition, at one concentration (the size of the read-out at that concentration, not a potency): > 90%
Compound 4: no number, only a limit (the forecaster's own chance of this, stated with the estimate: 60%); the middle value does not contradict the limit.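

Methyl on an aromatic carbon para to a large group leaves the read-out in this assay at the same limit as hydrogen and chloro at that position, so three different groups there now share it: the limit of > 90% in this assay, at which 3 of the 4 values shown sit. The steps to compound 4 from compound 1 and from compound 2 cannot be read, with a limit at both ends. Going by these compounds alone, the one step that can be read is a number at least 6.2 percentage points higher from compound 3 to compound 4 (that floor lies within the scatter), so this change establishes no difference beyond the scatter.

Compounds at the limit cannot be ranked against one another from a reading at a single concentration, so any differences among the three remain hidden. Going by these compounds, it also stays open whether an amine or a carboxylic acid on the same ring carbon would keep the read-out at the limit.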